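Side-chain swap on compound 1: notes toward compound 3

The source may report more compounds than this note shows. Statements on the series, on what has been measured and on what is new or still open speak of the compounds shown alone.

Measured so far:
- compound 1 `COC(=O)/C=C/C[C@H]1OCCC[C@@H]1O[Si](C)(C)C(C)(C)C`: 18000 nM
- compound 2 `COC(=O)/C=C/C[C@H]1OCCC[C@@H]1OC(=O)c1ccccc1`: "not active" (no number reported)

Among the measured compounds shown here, compound 1 is the only member with a number in a functional assay on MCF7S cells (Homo sapiens); on this read-out lower numbers stand for stronger inhibition of growth and higher numbers for weaker inhibition of growth; in that assay compound 1 gives 18000 nM. For the measured compounds named here, compound 2 is reported in this assay as "not active" (no number reported), without a number, so no step between the two can be sized. Compound 3 `CC(C)(C)[Si](C)(C)O[C@H]1CCCO[C@@H]1/C=C/CO` differs from compound 1 by 3-hydroxyprop-1-en-1-yl in place of 3-(methoxycarbonyl)prop-2-en-1-yl on a saturated ring carbon. Going by the values given here, no measured pair covers this change, so there is no step to lean on. Because compound 1 shows only weak inhibition at 18000 nM, the new compound is expected to stay in the same weak range. The change is estimated as a 1.4-fold higher number from compound 1 to compound 3 (0.14 log units; within the scatter), not clearly beyond the scatter, with a real risk that only a limit is reported. Compound 3 is estimated at 25000 nM, within 8000 nM to 80000 nM.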

Compound 3, concentration for 50% growth inhibition: 61000 nM
Compound 3: middle estimate off by 2.4-fold (0.39 log units), on the low side; low and high end bracket the measured number.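

Among the compounds shown here, the swap of 3-(methoxycarbonyl)prop-2-en-1-yl for 3-hydroxyprop-1-en-1-yl on a saturated ring carbon next to the ring oxygen gives the first step that can be read at this position in this assay: a 3.4-fold higher number from compound 1 to compound 3 (0.53 log units; beyond the scatter). The position therefore responds to the side chain, though only modestly, and the methoxycarbonyl group is not needed for a number: compound 3 still gives 61000 nM. No measurement at hand bears on the reason for this step.

The swap alters the end group and the chain together, so the compounds shown do not separate the two, and the step from compound 1 to compound 2 cannot be read. Open too, as far as these compounds go, is how a carboxylic acid, an amine or a longer chain at this position would read out in this assay.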